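Aryl-to-piperidinyl exchange at the amine of compound 2

This account rests on a few compounds, and the source may have more. Where it says the series, first, only, none or still open, it means among the compounds named here.

Measured compounds:
compound 1 `COc1ncc(-c2ccc3ncc(NCc4ccc(C(F)(F)F)cc4)c(OC)c3c2)cc1NS(=O)(=O)c1ccc(F)cc1F` — 2880 nM
compound 2 `COc1ccc(CNc2cnc3ccc(-c4cnc(OC)c(NS(=O)(=O)c5ccc(F)cc5F)c4)cc3c2OC)cc1` — 4520 nM

In a functional assay on PC-3 cells (Homo sapiens) for antiproliferative activity, read by sulforhodamine B assay, with a stated time of 72 h (a higher number here means a weaker inhibitor, a lower number a stronger inhibitor), compound 1 gives 2880 nM and compound 2 gives 4520 nM. Within the data shown here, compound 2 holds the higher of the two numbers, yet its only neighbour is compound 1 and the step of a 1.6-fold higher number from compound 1 to compound 2 (0.20 log units; within the scatter) lies within the scatter, so no order between the two can be read.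

Compound 3 `COc1ncc(-c2ccc3ncc(NCC4CCN(S(C)(=O)=O)CC4)c(OC)c3c2)cc1NS(=O)(=O)c1ccc(F)cc1F` differs from compound 2 by 1-(methylsulfonyl)piperidin-4-yl in place of 4-methoxyphenyl on a saturated chain carbon bound to a nitrogen on an aromatic ring. Among the measured compounds shown here, the single measured step, a 1.6-fold higher number from compound 1 to compound 2 (0.20 log units; within the scatter), concerns the same arm of the molecule, methoxy in place of trifluoromethyl on an aromatic carbon, but it keeps the aromatic ring; the exchange of that ring for 1-(methylsulfonyl)piperidin-4-yl has no measured counterpart. For the measured compounds named here, the one available step being within the scatter, nothing here supports a step in either direction beyond the scatter.

The step to compound 3 is therefore expected as a 1.0-fold lower number from compound 2 to compound 3 (0.00 log units; within the scatter), with wide uncertainty. Compound 3 is estimated at 4500 nM in this assay, within a range of 1200 nM to 17000 nM.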

Compound 3, half-maximal inhibitory concentration: 2850 nM
Compound 3: middle estimate off by 1.6-fold (0.20 log units), on the high side; measured number inside the range.
By their numbers in this assay, from the lowest: compounds 3, 1 and 2 (each within the scatter of the next).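

In this assay, exchanging the aromatic ring itself for 1-(methylsulfonyl)piperidin-4-yl gives a 1.6-fold lower number from compound 2 to compound 3 (0.20 log units; within the scatter) and, with 4-(trifluoromethyl)phenyl as the group replaced, a 1.0-fold lower number from compound 1 to compound 3 (0.00 log units; within the scatter), both within the scatter. The earlier pair varied only a substituent on a retained aromatic ring, whereas these steps show that, on a saturated chain carbon bound to a nitrogen on an aromatic ring, a six-membered non-aromatic ring carrying methylsulfonyl on its nitrogen can stand in place of either aromatic group with no readable difference in this cell assay. No supporting measurement is available to explain this result or to extend it beyond these three compounds.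

Open, as far as these compounds go, is whether the methylsulfonyl group contributes at all, a question that the free piperidine amine or a carboxylic acid on the same ring would address. Also open, from the compounds shown here alone, is whether any group at this position can move the number beyond the scatter, for example a longer chain between the ring and the amine nitrogen or a small alkyl group such as cyclopropyl in place of the ring.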